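Replacing chloromethyl with (sec-butyl)amino on compound 3

The compounds below may be only part of what the source reports. "The series", "measured", "known", "first", "only" and "open" are said of these compounds alone.

In a functional assay for inhibition, with Homo sapiens as the target (a lower number here means that less compound is needed, a higher number that more compound is needed for the effect), compound 3 (`O=C1CCC(c2ccc(NC(=O)CCCl)cc2)=NN1`) gives 0.98 ug/mL and lies within the scatter of compound 1 (`CCCC(=O)Nc1ccc(C2=NNC(=O)CC2)cc1`) at 1.44 ug/mL while compound 2 (`CC(Cl)C(=O)Nc1ccc(C2=NNC(=O)CC2)cc1`) gives 0.45 ug/mL as the lowest number. The measured steps are small: a 1.5-fold lower number from compound 1 to compound 3 (0.17 log units; within the scatter) and a 2.2-fold higher number from compound 2 to compound 3 (0.34 log units; beyond the scatter) and a 3.2-fold lower number from compound 1 to compound 2 (0.51 log units; beyond the scatter) on side chains that all end in carbon or chlorine. Compound 4 (`CCC(C)NCC(=O)Nc1ccc(C2=NNC(=O)CC2)cc1`) brings a different change ((sec-butyl)amino in place of chloromethyl on a saturated chain carbon bound to a carbonyl carbon) with (sec-butyl)amino in place of chloromethyl on a saturated chain carbon bound to a carbonyl carbon. Within the data shown here, no measured compound carries an amino group there, so these steps guide the expectation only loosely. The expected outcome is a 1.5-fold higher number from compound 3 to compound 4 (0.18 log units; within the scatter) and leans toward a higher number. Compound 4 is estimated at 1.5 ug/mL with an expected range from 0.4 ug/mL to 6 ug/mL here.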

Compound 4, half-maximal effective concentration: about 21.5 ug/mL
Compound 4: the middle estimate sits 14-fold (1.16 log units) below what was measured; measured number above the stated range.
By their numbers in this assay, from the lowest: compound 2; then compounds 3 and 1 (each within the scatter of the next); then compound 4.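

In this assay, among these compounds, (sec-butyl)amino on a saturated chain carbon bound to a carbonyl carbon gives much larger steps than any seen among the earlier compounds: a 22-fold higher number from compound 3 to compound 4 (1.34 log units; beyond the scatter), a 48-fold higher number from compound 2 to compound 4 (1.68 log units; beyond the scatter) and a 15-fold higher number from compound 1 to compound 4 (1.17 log units; beyond the scatter). This side chain therefore responds strongly to this change, although propyl, 1-chloroethyl and 2-chloroethyl differ from one another by modest steps at most. Nothing available explains the rise.

From the compounds shown here alone, it remains open whether a plain amino group or a dimethylamino group would give a similar number. An ether of the same chain length could show whether the result follows the nitrogen or the sec-butyl group.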